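The compounds below may be only part of what the source reports. "The series", "measured", "known", "first", "only" and "open" are said of these compounds alone.

Measured compounds in an assay on a protein complex for inhibition of CDK8/Cyclin C (Homo sapiens), with a stated time of 1 h; on this read-out higher numbers stand for weaker inhibition and lower numbers for stronger inhibition:
compound 1, `NNC(=O)CCc1ccncc1-c1ccc2ccccc2c1`: 7.7 nM
compound 2, `CCOC(=O)/C=C/c1ccncc1-c1ccc2ccccc2c1`: 53.3 nM
compound 3, `O=C(O)CCNC(=O)/C=C/c1ccncc1-c1ccc2ccccc2c1`: 870 nM

Compound 3 has the highest number of the three. Its nearest neighbour is compound 2, with a 16-fold higher number from compound 2 to compound 3 (1.21 log units; beyond the scatter); compound 1 lies further away, as the two values show. Compound 4, `O=C(/C=C/c1ccncc1-c1ccc2ccccc2c1)NC1CC1`, differs from compound 3 by cyclopropyl in place of 2-carboxyethyl on an amide-type nitrogen. The step that bears on this change is a 16-fold higher number from compound 2 to compound 3 (1.21 log units; beyond the scatter), where the same amide nitrogen substituent entered and the number rose sharply; a 6.9-fold higher number from compound 1 to compound 2 (0.84 log units; beyond the scatter) touches the same side chain only loosely. Removing the 2-carboxyethyl group is therefore expected to lower the number, though not necessarily back to the level of compound 2. For compound 4 the estimate is 100 nM, with a range from 30 nM to 400 nM, meaning an expected step of an 8.7-fold lower number from compound 3 to compound 4 (0.94 log units; beyond the scatter).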

Compound 4, half-maximal inhibitory concentration: 40.1 nM
Compound 4: middle estimate off by 2.5-fold (0.40 log units), on the high side, within the range that was stated.
By their numbers in this assay, from the lowest: compound 1; then compounds 4 and 2 (each within the scatter of the next); then compound 3.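

Cyclopropyl in place of 2-carboxyethyl on the amide-type nitrogen gives a 22-fold lower number from compound 3 to compound 4 (1.34 log units; beyond the scatter) and shows that an amide at this carbonyl carbon can carry a low number, so the high number of compound 3 goes with its 2-carboxyethyl group. Cyclopropylamino in place of ethoxy on the carbonyl carbon gives a 1.3-fold lower number from compound 2 to compound 4 (0.12 log units; within the scatter) and leaves the two apart by no more than scatter, while the side chain of compound 1 remains ahead, with a 5.2-fold higher number from compound 1 to compound 4 (0.72 log units; beyond the scatter) as the step to compound 4. Nothing measured here explains these steps.

On these data alone, whether a simple methyl group, a longer chain or a chain ending in an amine on this nitrogen would stay near compound 4 remains open. So does whether a carboxylic acid placed closer to the nitrogen would carry the same penalty.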